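This account rests on a few compounds, and the source may have more. Where it says the series, first, only, none or still open, it means among the compounds named here.

Measured in a functional assay on PRK cells (Oryctolagus cuniculus) for cytotoxicity; a higher number here means that more compound is tolerated, a lower number that less compound is tolerated:
compound 1 `CCCCOC(=O)C(O)Cn1cnc2c(N)ncnc21`: 200 ug/mL
compound 2 `CC(C)OC(=O)C(O)Cn1cnc2c(N)ncnc21`: > 400 ug/mL, a limit of the assay and not a number
compound 3 `Nc1ncnc2c1ncn2CC(O)C(=O)OC1CCCCC1`: 100 ug/mL

Compound 2 stands only at the limit of > 400 ug/mL in this assay, at which 1 of the 3 values shown sits, in this assay. The step to compound 4 `CCCCCOC(=O)C(O)Cn1cnc2c(N)ncnc21` is pentyl in place of isopropyl on an oxygen next to a carbonyl group. Steps that bear on it: an at least 2.0-fold higher number from compound 1 to compound 2 (0.30 log units; that floor lies within the scatter), reaching the limit; an at least 4.0-fold lower number from compound 2 to compound 3 (0.60 log units; beyond the scatter), the one measured step away from compound 2 that gives a number; and a 2.0-fold lower number from compound 1 to compound 3 (0.30 log units; within the scatter). Compound 1 carries butyl and gives 200 ug/mL, so the pentyl chain of compound 4 is expected to give a number in this assay near that of compound 1 rather than one as high as that of compound 2, a drop probably beyond the scatter. For compound 4 the expected step is an at least 2.6-fold lower number from compound 2 to compound 4 (0.42 log units; beyond the scatter). Compound 4 is therefore estimated at 150 ug/mL, ranging from 50 ug/mL to 400 ug/mL.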

Compound 4, minimum cytotoxic concentration: 200 ug/mL
The estimate for compound 4 lay 1.3-fold (0.12 log units) below the measured number; the measured number falls inside the stated range.
By their numbers in this assay, from the lowest: compounds 3, 1 and 4 (each within the scatter of the next). At a limit, above all of these: compound 2.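

In this assay, butyl to pentyl on an oxygen next to a carbonyl group gives no change at the digits printed from compound 1 to compound 4 (within the scatter), and pentyl in place of cyclohexyl gives a 2.0-fold higher number from compound 3 to compound 4 (0.30 log units; within the scatter), so neither change separates these esters here. Compound 2 stands at > 400 ug/mL, which is a limit of the assay and not a number. Pentyl in place of isopropyl can therefore be read only as an at least 2.0-fold lower number from compound 2 to compound 4 (0.30 log units; that floor lies within the scatter).

Going by these compounds, how a longer chain such as heptyl reads at this position remains open. So does the reading for a free carboxylic acid or an amide in place of the ester.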